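The compounds below may be only part of what the source reports. "The series", "measured", "known", "first", "only" and "open" are said of these compounds alone.

Measured in a functional assay on A549 cells (Homo sapiens) for antiproliferative activity, read by MTT assay, with a stated time of 48 h; on this read-out lower numbers stand for stronger inhibition of growth and higher numbers for weaker inhibition of growth:
- compound 1 `COC(=O)N1N=C(c2cccc(O)c2)CC1c1cc(OC)c(OC)c(OC)c1`: 3170 nM
- compound 2 `COC(=O)N1N=C(c2cccc(C)c2)CC1c1cc(OC)c(OC)c(OC)c1`: 300 nM

Of these two, compound 2 has the lower number, with 300 nM against the higher reading of compound 1 at 3170 nM in this assay. Compound 3 `COC(=O)N1N=C(c2cccc(Cl)c2)CC1c1cc(OC)c(OC)c(OC)c1` keeps the shared core and carries chloro in place of methyl on an aromatic carbon, meta to a large group chloro in place of methyl on an aromatic carbon in its one point of difference from compound 2. For the measured compounds named here, the only measured step bearing on this place is an 11-fold lower number from compound 1 to compound 2 (1.02 log units; beyond the scatter), a large one, and it exchanged hydroxy for methyl. Going by the values given here, no measured pair exchanges methyl for chloro, so that step sets no direct size for this change. The expectation is therefore no step beyond the scatter in this assay, with the estimate being a 1.1-fold higher number from compound 2 to compound 3 (0.03 log units; within the scatter) here. Compound 3 is expected at 320 nM, with an estimated range of 110 nM to 950 nM in this assay.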

Compound 3, concentration for 50% growth inhibition: 340 nM
Estimate against measurement, compound 3: 1.1-fold (0.03 log units) below; the measured number falls inside the stated range.
By their numbers in this assay, from the lowest: compounds 2 and 3 (each within the scatter of the next); then compound 1.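

On the 3-substituted phenyl ring, the change from 3-methylphenyl to 3-chlorophenyl gives a 1.1-fold higher number from compound 2 to compound 3 (0.05 log units; within the scatter) in this assay, so this read-out does not separate chloro from methyl at this position. Chloro in place of hydroxy gives a 9.3-fold lower number from compound 1 to compound 3 (0.97 log units; beyond the scatter) in the same assay, which shows that the gap first seen with methyl is not unique to methyl and that, of the three groups shown here, hydroxy is the one that stands apart. No measurement shown offers an explanation for these results.

The compounds shown leave open whether an amine or a carboxylic acid at this position would read like hydroxy or like methyl and chloro. They also leave open whether chloro and methyl would remain level at another position on this ring.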